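Phenyl for methyl on a thiazole hydrazone: an open question

The compounds below may be only part of what the source reports. "The series", "measured", "known", "first", "only" and "open" are said of these compounds alone.

Compound 1, `C/C(=N\Nc1nc(-c2ccccc2)cs1)c1sc(C)nc1C`, in a toxicity assay on MCF7 cells (Homo sapiens) for cytotoxicity, read by MTT assay (on this read-out lower numbers stand for stronger inhibition of growth and higher numbers for weaker inhibition of growth), gives > 100 ug/mL, which is a limit of the assay.
Compound 2, `C/C(=N\Nc1nc(-c2ccc(F)cc2)cs1)c1sc(C)nc1C`, in this assay gives > 100 ug/mL, which is a limit of the assay.
Compound 3, `C/C(=N\Nc1nc(-c2ccc(C)cc2)cs1)c1sc(C)nc1C`, in this assay gives > 100 ug/mL, which is a limit of the assay.

Compound 2 therefore stands where every measured compound stands, at the limit of > 100 ug/mL in this assay, at which 3 of the 3 values shown sit; no number separates it from compound 1 or compound 3. The three measured steps, a step that the two limits leave unreadable from compound 1 to compound 2, a step that the two limits leave unreadable from compound 1 to compound 3 and a step that the two limits leave unreadable from compound 2 to compound 3, all concern the six-membered ring attached to the shared core, and none of them can be read in size.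

Compound 4, `C/C(=N\Nc1nc(-c2ccc(F)cc2)cs1)c1sc(-c2ccccc2)nc1C`, differs from compound 2 in another place: phenyl in place of methyl on an aromatic carbon. Among the compounds with values here, no measured step touches this methyl group, so nothing measured bears on the change directly. Within the data shown here, the only guide is that each of the three measured compounds sits at the limit. The step from compound 2 to compound 4 in this assay is therefore expected to be a step that the limit leaves unreadable from compound 2 to compound 4, with a fair chance that the assay again reports only a limit. The estimate for compound 4 in this assay is 120 ug/mL, within a range from 40 ug/mL to 400 ug/mL.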

Compound 4, concentration for 50% growth inhibition: > 100 ug/mL
Compound 4 ended at the assay's limit (the forecaster's own chance of this, stated with the estimate: 65%); the middle value lies beyond the limit too.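

Compound 2 and compound 4 both give only a limit in this assay, so the step between them cannot be read in size: the limit of > 100 ug/mL in this assay, at which 4 of the 4 values shown sit.

The compounds shown leave open how far each lies past that limit, and whether any change to the shared core gives a readable value.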